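The compounds below may be only part of what the source reports. "The series", "measured", "known", "first", "only" and "open" are said of these compounds alone.

Measured in an ADME assay (liver) for metabolic stability, with Liver microsome (Rattus norvegicus) as the target, read by LC-MS, using microsomes, with a stated time of 30 min, tested at 4 uM; a lower number here means that less of the compound is left, a higher number that more of the compound is left:
- compound 1 `Cc1nc(N2CCN(C)CC2)c2nc(-c3cccc(C(F)(F)F)c3)n(C3CCOCC3)c2n1`: 28%
- compound 2 `Cc1nc(N2CCN(C)CC2)c2nc(-c3ccccc3C#N)n(C3CCOCC3)c2n1`: 21%
- compound 3 `COc1ccc(-c2nc3c(N4CCN(C)CC4)nc(C)nc3n2C2CCOCC2)c(C)c1`: not yet measured

In this small set, compound 2 gives 21%, within the scatter of compound 1 at 28%. The next change is 4-methoxy-2-methylphenyl in place of 2-cyanophenyl on an aromatic carbon: 4-methoxy-2-methylphenyl in place of 2-cyanophenyl, on an aromatic carbon of the five-membered aromatic ring with 2 nitrogen. Going by the values given here, the one measured step at this place is a number 7 percentage points lower from compound 1 to compound 2 (within the scatter), and it lies within the scatter. Among the compounds with values here, no measured compound carries 4-methoxy-2-methylphenyl, so this single step is weak guidance. No change beyond the scatter is expected in this assay. The expected step is a number 1 percentage points lower from compound 2 to compound 3 (within the scatter). For compound 3 the estimated value is 20%, with an expected range from 8% to 36%.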

Compound 3, percent of the compound remaining: 24%
Estimate against measurement, compound 3: 4 percentage points below, within the range that was stated.
By their numbers in this assay, from the lowest: compounds 2, 3 and 1 (each within the scatter of the next).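

At the aromatic carbon next to the ring atom that bears the oxan-4-yl group, 4-methoxy-2-methylphenyl in place of 2-cyanophenyl gives, in this assay, a small step (a number 3 percentage points higher from compound 2 to compound 3 (within the scatter)), and in place of 3-(trifluoromethyl)phenyl it also gives a small step (a number 4 percentage points lower from compound 1 to compound 3 (within the scatter)). A third substitution pattern on the phenyl ring, now with methoxy and methyl groups, therefore does not separate from the nitrile or trifluoromethyl compounds, and all three compounds lie within the scatter of one another. No supporting data bear on what lies behind these readings.

Going by these compounds, it remains open whether an amine or a carboxylic acid on the phenyl ring, or a pyridine ring in its place, would move the reading beyond the scatter. On these data alone, the effect of replacing the oxan-4-yl group, which all three compounds carry, is also open.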